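The source may hold more compounds than are shown below. What is called first, only, known or untested is meant among the compounds shown, and "the series" means these compounds.

Of the compounds shown here, three built on one shared core have been measured so far. Compound 1 `Cc1ccc(C(C2c3onc(C)c3N=C(c3ccccc3)CC2c2ccccc2)C2c3onc(C)c3N=C(c3ccccc3)CC2c2ccccc2)cc1` carries a methyl group on a benzene ring hanging from that core; in a functional assay on Ehrlich cells (Homo sapiens) for cytotoxicity, read by MTT assay, with a stated time of 48 h (a higher number here means a weaker inhibitor, a lower number a stronger inhibitor), compound 1 gives 48.2 ug/mL. Compound 2 `Cc1noc2c1N=C(c1ccccc1)CC(c1ccccc1)C2C(c1ccc(Cl)cc1)C1c2onc(C)c2N=C(c2ccccc2)CC1c1ccccc1` carries a chloro group in the same spot, and in this assay compound 2 gives 60.4 ug/mL. Compound 3 `COc1ccc(C(C2c3onc(C)c3N=C(c3ccccc3)CC2c2ccccc2)C2c3onc(C)c3N=C(c3ccccc3)CC2c2ccccc2)cc1` carries a methoxy group there, and in this assay compound 3 gives 41.9 ug/mL. Compound 3 thus holds the smallest of the three numbers, yet every gap to it lies within the usual scatter: a 1.2-fold lower number from compound 1 to compound 3 (0.06 log units; within the scatter) and a 1.4-fold lower number from compound 2 to compound 3 (0.16 log units; within the scatter), and likewise a 1.3-fold higher number from compound 1 to compound 2 (0.10 log units; within the scatter) between the other two.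

Compound 4 `Cc1noc2c1N=C(c1ccccc1)CC(c1ccccc1)C2C(c1ccccc1)C1c2onc(C)c2N=C(c2ccccc2)CC1c1ccccc1` has not yet been measured. It differs from compound 3 in one place: hydrogen in place of methoxy on an aromatic carbon. Going by the values given here, the steps that bear on this swap all exchange the same aromatic substituent, and none of them moved the number beyond the scatter, whether methyl, chloro or methoxy stood there. Taking that substituent away altogether is therefore expected to give no step beyond the scatter, that is a 1.1-fold higher number from compound 3 to compound 4 (0.05 log units; within the scatter). The estimate for compound 4 in this assay is 47 ug/mL, with a range from 30 ug/mL to 75 ug/mL.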

Compound 4, half-maximal inhibitory concentration: 66.5 ug/mL
Beside the measured number, compound 4's estimate is 1.4-fold (0.15 log units) below it; the range from low to high includes it.
By their numbers in this assay, from the lowest: compounds 3, 1, 2 and 4 (each within the scatter of the next).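

Going by these compounds alone, compound 4 adds what the earlier compounds could not show: the case with no substituent at all on this aromatic carbon, where the 4-methoxyphenyl becomes a plain phenyl. In this assay, within the data shown here, the new steps are a 1.6-fold higher number from compound 3 to compound 4 (0.20 log units; within the scatter) and a 1.1-fold higher number from compound 2 to compound 4 (0.04 log units; within the scatter) and also a 1.4-fold higher number from compound 1 to compound 4 (0.14 log units; within the scatter) so bare hydrogen cannot be told apart from methoxy, chloro or methyl here, and across these four compounds the position, on a six-membered aromatic ring of carbon only and para to a large group, shows no sensitivity to the swap, with no compound going against that reading. Nothing available explains why these numbers stay so close together.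

Still open, going by these compounds, is whether a group of a different kind at this place, such as an amine, a carboxylic acid or a longer chain, would produce a step beyond the scatter. The compounds shown also leave open whether the same close agreement would hold after a change to the shared core itself, since all four differ only in this one substituent.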